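Sulfamoyl on the piperazine: expected cytotoxicity shift

The source may report more compounds than this note shows. Statements on the series, on what has been measured and on what is new or still open speak of the compounds shown alone.

Compound 2 `Cc1cc(/C=C/C#N)cc(C)c1Oc1nc(Nc2ccc(CN3CCNCC3)cc2)nc2sccc12`, compound 3 `Cc1cc(/C=C/C#N)cc(C)c1Oc1nc(Nc2ccc(N3CCNCC3)cc2)nc2ccsc12` and compound 1 `Cc1cc(/C=C/C#N)cc(C)c1Oc1nc(Nc2ccc(N3CCCC(NS(N)(=O)=O)C3)cc2)nc2ccsc12` share one core and differ only in the group on the aromatic carbon of the aniline ring. In an ADME assay on MT4 cells (Homo sapiens) for cytotoxicity, read by MTT assay, with a stated time of 5 days (a higher number here means that more compound is tolerated, a lower number that less compound is tolerated), compound 2 gives 4030 nM. Compound 3 gives 5730 nM in this assay, which lies within the scatter of the number for compound 2. For compound 1 this assay reports only a limit, > 217000 nM, not a number. For the measured compounds named here, the one step measured in one place, an at least 37-fold lower number from compound 1 to compound 3 (1.57 log units; beyond the scatter), shows that removing the sulfamoyl-bearing ring goes with a much lower tolerated concentration.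

Compound 4 `Cc1cc(/C=C/C#N)cc(C)c1Oc1nc(Nc2ccc(N3CCN(S(N)(=O)=O)CC3)cc2)nc2sccc12` is not yet measured. It differs from compound 2 by 4-sulfamoylpiperazin-1-yl in place of (piperazin-1-yl)methyl on an aromatic carbon. This change brings a sulfamoyl group back onto the amine ring and attaches that ring directly to the aromatic carbon, so the step from compound 1 to compound 3 is the closest guide, read in the opposite direction, although the ring and the point of attachment of the sulfamoyl group are not the same. A large step toward a higher number is therefore expected in this assay, with a real chance that only a limit is reported, as for compound 1 at the limit of > 217000 nM in this assay, at which 1 of the 3 values shown sits. Compound 4 is expected to give about 100000 nM, within a range of 20000 nM to 250000 nM. The expected step is a 25-fold higher number from compound 2 to compound 4 (1.39 log units; beyond the scatter).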

Compound 4, half-maximal cytotoxic concentration: > 222000 nM
Compound 4: a limit, no number; the forecaster's own chance of this, stated with the estimate: 50%; middle value at least 2.2-fold (0.34 log units) from the limit.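

In this assay, the change to 4-sulfamoylpiperazin-1-yl gives an at least 55-fold higher number from compound 2 to compound 4 (1.74 log units; beyond the scatter), a large step in a second pair of compounds. The pair already in hand reads the same way from the other side, with an at least 37-fold lower number from compound 1 to compound 3 (1.57 log units; beyond the scatter), so the link between a sulfamoyl-bearing amine ring on this aromatic carbon and a higher number now holds for a sulfamoyl group on a piperazine ring as well as for a sulfamoylamino group on a piperidine ring, and neither pair goes against it. Compound 4 gives a limit of the assay and not a number: the limit of > 222000 nM in this assay, at which 1 of the 4 values shown sits.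

The step replaces (piperazin-1-yl)methyl as a whole, so the sulfamoyl group and the loss of the methyl link are not separated, and a (4-sulfamoylpiperazin-1-yl)methyl group or a 4-acetylpiperazin-1-yl group would be needed to tell them apart. Going by these compounds, compound 1 also stands at a limit, so the full size of both steps stays open and compound 1 and compound 4 cannot be placed in order.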